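Dimethylamino on compound 2: a cytotoxicity limit held?

The source may hold more compounds than are shown below. What is called first, only, known or untested is meant among the compounds shown, and "the series" means these compounds.

- Compound 1 `O=c1c(O)cccn1Cc1ccccc1`: > 10 ug/mL, a limit
- Compound 2 `O=c1c(O)cccn1Cc1ccc(-c2ccccc2)cc1`: > 10 ug/mL, a limit
- Compound 3 `Cc1cccc(-c2ccc(Cn3cccc(O)c3=O)cc2)c1`: > 10 ug/mL, a limit

All three results come from an ADME assay on THP-1 cells (Homo sapiens) for cytotoxicity, read by resazurin assay, with a stated time of 48 h (a lower number here means a stronger inhibitor, a higher number a weaker inhibitor), and the common picture is the limit of > 10 ug/mL in this assay, at which 3 of the 3 values shown sit. Compound 2 has no number in this assay. It stands only at > 10 ug/mL, which is a limit.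

Compound 4 `CN(C)c1ccc(-c2ccc(Cn3cccc(O)c3=O)cc2)cc1` has not yet been measured. It differs from compound 2 by dimethylamino in place of hydrogen on an aromatic carbon, so dimethylamino takes the place of hydrogen on an aromatic carbon.

Among the measured compounds shown here, three measured steps bear on this change: a step that the two limits leave unreadable from compound 1 to compound 2, a step that the two limits leave unreadable from compound 1 to compound 3 and a step that the two limits leave unreadable from compound 2 to compound 3. The last is the closest, as it also adds a small group to compound 2. None of the three has a readable size, so they give no direction, and no step beyond the scatter is expected. The estimated outcome is a step that the limit leaves unreadable from compound 2 to compound 4. For compound 4 the expected value is 14 ug/mL, with an estimated range of 6 ug/mL to 40 ug/mL.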

Compound 4, half-maximal inhibitory concentration: > 10 ug/mL
Compound 4 ended at the assay's limit; the forecaster's own chance of this, stated with the estimate: 75%; the middle value does not contradict the limit.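

Compound 4, like compound 2, stands only at a limit in this assay, so no step can be read between the two. The compounds shown leave open what actual value any of them would give in this assay, and so whether dimethylamino changes it at all.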